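This account rests on a few compounds, and the source may have more. Where it says the series, first, only, none or still open, it means among the compounds named here.

Compound 1 `COc1ccccc1/C=N/NC(=O)CSc1nnnn1C` gives 7000000 nM in a functional assay on A549 cells (Homo sapiens) for cytotoxicity, read by XTT assay, with a stated time of 24 h; on this read-out lower numbers stand for stronger inhibition and higher numbers for weaker inhibition. Compound 3 `Cc1ccccc1/C=N/NC(=O)CSc1nnnn1C` reaches only the limit of this assay, > 10000000 nM. Compound 2 `COc1cccc(/C=N/NC(=O)CSc2nnnn2C)c1` likewise stops at the limit, > 10000000 nM. Compound 1 and compound 2 share the same atoms joined differently; the difference between the two cores is not broken down here. Compound 3 arises from compound 1 by methyl in place of methoxy on an aromatic carbon, and that change gives an at least 1.4-fold higher number from compound 1 to compound 3 (0.15 log units; that floor lies within the scatter), a floor set because of the limit of > 10000000 nM in this assay, at which 2 of the 3 values shown sit. Compound 4 `Cc1cccc(/C=N/NC(=O)CSc2nnnn2C)c1` stands to compound 2 in the same kind of change, (methyl in place of methoxy on an aromatic carbon), though here the group sits meta to a large group rather than ortho. The step from compound 2 to compound 4 is expected to be a step that the limit leaves unreadable from compound 2 to compound 4, resting on an at least 1.4-fold higher number from compound 1 to compound 3 (0.15 log units; that floor lies within the scatter). Compound 4 is therefore expected near 15000000 nM, between 7000000 nM and 40000000 nM.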

Compound 4, half-maximal inhibitory concentration: 2000000 nM
For compound 4 the middle estimate is 7.5-fold (0.88 log units) above the measured one; the measured number lies below the stated range.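

In this assay, methyl in place of methoxy gives an at least 5.0-fold lower number from compound 2 to compound 4 (0.69 log units; beyond the scatter), and the change does not carry from one core to the other as a fixed step: the same change on two cores in this assay, an at least 1.4-fold higher number (0.15 log units; that floor lies within the scatter) from compound 1 to compound 3 and an at least 5.0-fold lower number (0.69 log units; beyond the scatter) from compound 2 to compound 4, at least 7.1-fold (0.85 log units) apart, beyond the scatter of two such steps. Neither step has a known full size, and each is only a floor set by a limit of the assay: the limit of > 10000000 nM in this assay, at which 2 of the 4 values shown sit. Within the data shown here, with only two cores compared, this shows that the outcome of the change depends on the core in these compounds, but it does not show what sets the two steps apart or give a rule for the wider series.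

The compounds shown leave open how an amine, a hydroxyl group or a chlorine atom in the same place would read on either core. They also leave open where compound 2 and compound 3 would fall beyond their limits.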